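The source may hold more compounds than are shown below. What is called first, only, known or untested is meant among the compounds shown, and "the series" means these compounds.

Within the data shown here, compound 1 `Cc1cc(OCCCCCCC[N+]2(C)CCCC2)cc(-n2cc(C(=O)Nc3cc(F)cc(F)c3)c(=O)c3ccc(N(C)C)nc32)c1` is the only compound in this set with a number attached to it. In an assay on LX2 cells for inhibition of COL1A1 promoter (Homo sapiens), read by a luciferase reporter, with a stated time of 24 h, tested at 20 uM (on this read-out lower numbers stand for a weaker effect and higher numbers for a stronger effect at the one concentration tested), compound 1 gives 4.32%, a small effect at the single concentration tested. Compound 2 `CC[N+]1(CCCCCCCOc2ccc(-n3cc(C(=O)Nc4cc(F)cc(F)c4)c(=O)c4ccc(N(C)C)nc43)c(F)c2)CCCCC1` was also run; in this assay compound 2 gives "not active" (no number reported), a report without a number, so the two cannot be set side by side by size. Compound 3 `CC[N+]1(CCCCCCCOc2cc(C)cc(-n3cc(C(=O)Nc4cc(F)cc(F)c4)c(=O)c4ccc(N(C)C)nc43)c2)CCCCC1` has not been measured. It differs from compound 1 in one place: a group of 8 heavy atoms (7 carbon, 1 nitrogen; one six-membered non-aromatic ring with 1 hetero atom) in place of a group of 6 heavy atoms (5 carbon, 1 nitrogen; one five-membered non-aromatic ring with 1 hetero atom), on a saturated chain carbon, seven bonds along the chain from an oxygen on an aromatic ring. Among the measured compounds shown here, no step between two measured compounds is available to size this kind of change, and compound 2 differs from both in more than one place, so it offers no guide. With compound 1 showing only a weak effect in this assay, the expected step is a number 0.3 percentage points lower from compound 1 to compound 3 (within the scatter), that is, nothing beyond the ordinary scatter of the read-out. Compound 3 is therefore estimated at 4%, with a plausible range from 0% to 14%. Whether a number will be reported at all is uncertain, given that compound 2 came back without one.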

Compound 3, a percentage reported as inhibition, at one concentration (the size of the read-out at that concentration, not a potency): 67.2%
Beside the measured number, compound 3's estimate is 63.2 percentage points below it; measured number outside the range, above it.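

At this place, on a saturated chain carbon, seven bonds along the chain from an oxygen on an aromatic ring, this assay gives a number 62.9 percentage points higher from compound 1 to compound 3 (beyond the scatter) when a group of 8 heavy atoms with one six-membered non-aromatic ring replaces a group of 6 heavy atoms with one five-membered non-aromatic ring. Both groups carry a net charge of +1 and have no hydrogen-bond donors or acceptors, so these counts do not separate them, yet the read-out changes from a small effect to a large one, showing that this end of the chain is far from indifferent to the group it carries. No measurement available here explains why this change has such a large effect.

The compounds shown cannot separate the size of the ring from the other carbon atoms that enter with the larger group, since both change together in this one step. Going by these compounds, how a morpholine ring or a seven-membered ring at this place would read remains open, as does whether a longer chain would keep the effect seen with compound 3.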